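Adding a hydroxy group to compound 3: cytotoxicity outlook

The compounds below may be only part of what the source reports. "The series", "measured", "known", "first", "only" and "open" are said of these compounds alone.

Three compounds have so far been run in a functional assay on HT-1080 cells (Homo sapiens) for cytotoxicity, read by MTT assay, with a stated time of 72 h; on this read-out lower numbers stand for stronger inhibition and higher numbers for weaker inhibition. Compound 1 `O=C1C[C@@H](c2ccccc2)Oc2cc(O)c(O)c(O)c21` returns only a limit, > 100000 nM. Compound 2 `COc1c(O)cc2c(c1O)C(=O)[C@H](O)[C@@H](c1ccccc1)O2` likewise returns a limit, > 100000 nM. Compound 3 `COc1ccc(-c2coc3cc(O)ccc3c2=O)c(O)c1` also gives a limit in this assay, > 100000 nM. Among the compounds with values here, no pair among compounds 1, 2 and 3 differs in a single place, so no measured step can be counted; all the numbers show is the limit of > 100000 nM in this assay, at which 3 of the 3 values shown sit, and compound 3 stands with the other two at that limit rather than at a number.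

Compound 4 `COc1ccc(-c2coc3cc(O)cc(O)c3c2=O)c(O)c1` has not yet been measured. It differs from compound 3 as follows: hydroxy in place of hydrogen on an aromatic carbon.

Within the data shown here, with no measured step to lean on and every compound run so far sitting at the limit, the step from compound 3 to compound 4 in this assay is expected to be none beyond the scatter, a number no higher from compound 3 to compound 4 (the limit leaves the size open). Compound 4 is accordingly expected to stay at the limit of this assay, with an estimate of 100000 nM and a range from 40000 nM to 300000 nM.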

Compound 4, half-maximal inhibitory concentration: > 100000 nM
Compound 4: only a limit was reported (the forecaster's own chance of this, stated with the estimate: 85%); the middle value sits exactly at the limit.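

Within the data shown here, compound 3 and compound 4 both return only limits in this assay, so no step between them can be read: the limit of > 100000 nM in this assay, at which 4 of the 4 values shown sit. As far as these compounds go, whether hydroxy in place of hydrogen on an aromatic carbon alters cytotoxicity stays open, as does where any of the four compounds would read as a number.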